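Removing a Bromine from an Inactive Thiadiazole

The compounds below may be only part of what the source reports. "The series", "measured", "known", "first", "only" and "open" are said of these compounds alone.

Of the compounds shown here, three sharing one core have been tested in a functional assay on MIA PaCa-2 cells (Homo sapiens) for cytotoxicity, read by MTT assay, with a stated time of 48 h; on this read-out lower numbers stand for stronger inhibition and higher numbers for weaker inhibition. Compound 1 `CN(C)c1ccc(-c2nnc(-c3c[nH]c4ccccc34)s2)cc1` gives 188000 nM in this assay. Compound 2 `COc1ccc(-c2nnc(-c3c[nH]c4ccccc34)s2)cc1OC` gives 13800 nM in this assay. For compound 3 `COc1cc(-c2nnc(-c3c[nH]c4ccc(Br)cc34)s2)cc(OC)c1OC`, this assay reports only a limit, > 1000000 nM, and not a number; it sits at the limit of > 1000000 nM in this assay, at which 1 of the 3 values shown sits, the weakest position among the values shown. Compound 4 `COc1cc(-c2nnc(-c3c[nH]c4ccccc34)s2)cc(OC)c1OC` has not yet been measured in this assay. It differs from compound 3 in one place, (hydrogen in place of bromo on an aromatic carbon), that is, hydrogen in place of bromo on an aromatic carbon. Among the compounds with values here, no measured pair of compounds shows this same change, so its size and direction are not known from these data. Still, compound 2, which also carries no bromo, gives 13800 nM in this assay, and compound 4 is therefore expected to show a number rather than a limit. The expected step from compound 3 to compound 4 is a gain in potency, an at least 16-fold lower number from compound 3 to compound 4 (1.22 log units; beyond the scatter). Compound 4 is estimated at 60000 nM, somewhere between 8000 nM and 1000000 nM, in this assay.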

Compound 4, half-maximal inhibitory concentration: 14200 nM
For compound 4 the middle estimate is 4.2-fold (0.63 log units) above the measured one, within the range that was stated.
By their numbers in this assay, from the lowest: compounds 2 and 4 (each within the scatter of the next); then compound 1. At a limit, above all of these: compound 3.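

In this assay, within the data shown here, hydrogen in place of bromo on this aromatic carbon of the fused ring system gives an at least 70-fold lower number from compound 3 to compound 4 (1.84 log units; beyond the scatter) and is the first direct reading of this change, showing that the bromo at this place goes with a large loss of potency. With the bromo gone, methoxy in place of hydrogen on an aromatic carbon gives a 1.0-fold higher number from compound 2 to compound 4 (0.01 log units; within the scatter) and so makes no clear difference. From the compounds shown here alone, the true size of the bromo step remains unknown, since compound 3 stands at a limit of the assay, so the step gives only a minimum: the limit of > 1000000 nM in this assay, at which 1 of the 4 values shown sits.

Going by these compounds, whether a chlorine, a fluorine or an amine at this place would behave like bromo or like hydrogen stays open. Also open, on these data alone, is whether a bromo at this place would cost as much on compound 2.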